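Pyridinyl to phenyl on the thioether side chain

The source may report more compounds than this note shows. Statements on the series, on what has been measured and on what is new or still open speak of the compounds shown alone.

Two members of the series share one core and differ only in the heteroaryl attached to the saturated chain carbon bound to sulfur. Compound 1 `CC(Sc1nc2c(cnn2C)c(=O)n1-c1ccccc1)c1ccccn1` gives 63 nM in an assay on isolated protein for inhibition of retinal dehydrogenase 2 (Homo sapiens); a higher number here means a weaker inhibitor, a lower number a stronger inhibitor. Compound 2 `CC(Sc1nc2c(cnn2C)c(=O)n1-c1ccccc1)c1cccnc1` gives 89 nM in this assay. The step of a 1.4-fold higher number from compound 1 to compound 2 (0.15 log units; within the scatter) shows that moving the ring nitrogen leaves the read-out essentially unchanged. Among the measured compounds shown here, on the two numbers so far, compound 2 holds the higher value, with compound 1 its only neighbour, and the two lie within the scatter of each other.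

Compound 3 `C[C@H](Sc1nc2c(cnn2C)c(=O)n1-c1ccccc1)c1ccccc1` is not yet measured in this assay. Its change from compound 2 is 1-phenylethyl in place of 1-(pyridin-3-yl)ethyl on a sulfur. For the measured compounds named here, no measured step removes the ring nitrogen outright; the one step that bears on it, from compound 1 to compound 2, only relocates it and stays within the scatter. On that basis the step of a 1.1-fold higher number from compound 2 to compound 3 (0.05 log units; within the scatter) is expected to be small, with no clear direction beyond the scatter. Compound 3 is therefore estimated at 100 nM in this assay, in the range 40 nM to 300 nM.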

Compound 3, half-maximal inhibitory concentration: 1480 nM
The estimate for compound 3 lay 15-fold (1.17 log units) below the measured number; measured number outside the range, above it.
By their numbers in this assay, from the lowest: compounds 1 and 2 (each within the scatter of the next); then compound 3.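

On the sulfur of the shared core, the two pyridinyl groups sit together, while the carbon-only ring stands well apart in this assay: 1-phenylethyl in place of 1-(pyridin-3-yl)ethyl gives a large loss (a 17-fold higher number from compound 2 to compound 3 (1.22 log units; beyond the scatter)), and 1-phenylethyl in place of 1-(pyridin-2-yl)ethyl gives one of similar order (a 23-fold higher number from compound 1 to compound 3 (1.37 log units; beyond the scatter)). The insensitivity seen when the ring nitrogen was relocated therefore does not extend to replacing that nitrogen with carbon, so this position responds strongly to a change that left the same number of heavy atoms. The change is not a clean one, however, as the entering 1-phenylethyl group carries a defined stereocentre, and no measurement here accounts for the loss in strength.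

The compounds shown leave open how much of the step belongs to the missing ring nitrogen and how much to the defined stereocentre, a question that the opposite enantiomer of the 1-phenylethyl compound would address. Also open, as far as these compounds go, is whether a 1-(pyridin-4-yl)ethyl group, or a 1-phenylethyl group with a methoxy or an amine on its ring, would recover the strength of the pyridinyl pair.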